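Swapping the urea side for an aryl ketone-type amide

The compounds below may be only part of what the source reports. "The series", "measured", "known", "first", "only" and "open" are said of these compounds alone.

compound 1 `O=C(NCCCCC(c1ccc(F)cc1)c1ccc(F)cc1)Nc1cccc([N+](=O)[O-])c1` gives 3790 nM in a functional assay on MDA-MB-231 cells (Homo sapiens) for cytotoxicity, read by MTT assay, with a stated time of 48 h; a higher number here means a weaker inhibitor, a lower number a stronger inhibitor
compound 2 `O=C(NCCCCC(c1ccc(F)cc1)c1ccc(F)cc1)Nc1ccc(Cl)c(C(F)(F)F)c1` gives 3150 nM in this assay
compound 3 `O=C(NCCCCC(c1ccc(F)cc1)c1ccc(F)cc1)Nc1ccc(Cl)cc1C(F)(F)F` gives > 20000 nM in this assay

Compound 3 stands at a limit, not a number (the limit of > 20000 nM in this assay, at which 1 of the 3 values shown sits). Compound 1 sits level with compound 2 (a 1.2-fold lower number from compound 1 to compound 2 (0.08 log units; within the scatter)). Compound 4 `O=C(NCCCCC(c1ccc(F)cc1)c1ccc(F)cc1)c1ccc(Cl)c(C(F)(F)F)c1` differs from compound 1 as follows: 4-chloro-3-(trifluoromethyl)phenyl in place of (3-nitrophenyl)amino on a carbonyl carbon. The new 4-chloro-3-(trifluoromethyl)phenyl is already known from compound 2, and that exchange alone was silent (a 1.2-fold lower number from compound 1 to compound 2 (0.08 log units; within the scatter)). The group on the amide-type nitrogen is not always silent, as compound 3 shows (an at least 6.3-fold higher number from compound 2 to compound 3 (0.80 log units; beyond the scatter)). Among the measured compounds shown here, the loss of the amino nitrogen beside the carbonyl carbon has no measured counterpart, so the expectation stays loose. A small step toward a higher number is expected (a 1.6-fold higher number from compound 1 to compound 4 (0.20 log units; within the scatter)). Compound 4 is estimated at 6000 nM (expected range 2000 nM to 20000 nM).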

Compound 4, half-maximal inhibitory concentration: 11700 nM
Compound 4: the middle estimate sits 2.0-fold (0.29 log units) below what was measured; the measured number falls inside the stated range.
By their numbers in this assay, from the lowest: compounds 2 and 1 (each within the scatter of the next); then compound 4. At a limit, above all of these: compound 3.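

In this assay the exchange on the carbonyl carbon is not silent: a 3.1-fold higher number from compound 1 to compound 4 (0.49 log units; beyond the scatter). The aryl exchange alone did not move the number, so the aryl group by itself does not account for this step. With the same 4-chloro-3-(trifluoromethyl)phenyl group present, compound 2, which keeps the amino nitrogen, gives 3150 nM, while compound 4, which lacks it, gives 11700 nM, pointing to that nitrogen as the part of the change that matters in this pair.

Compound 3 remains the only limit in the series, and a limit is not a number: the limit of > 20000 nM in this assay, at which 1 of the 4 values shown sits. Still open, going by these compounds, is whether a carbamate oxygen or a methylene on the carbonyl carbon would keep the number of compound 2, and whether the 3-nitrophenyl group would respond to the same exchange.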